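Ring size on the amide nitrogen and paw edema inhibition

The source may report more compounds than this note shows. Statements on the series, on what has been measured and on what is new or still open speak of the compounds shown alone.

Compound 1, `COc1cc2c(cc1OC)C(CC(N)=O)CC2`, gives 27.8% in a functional assay on the whole organism (strain Wistar) for inhibition, with Rattus norvegicus as the target, read by paw edema, with stated times of 60 min and 6 h, at a dose of 100 mg/kg by the oral route; a lower number here means less inhibition, a higher number more inhibition at the dose given (going by the name of the read-out).
Compound 2, `CNC(=O)CC1CCc2cc(OC)c(OC)cc21`, gives 24.1% in this assay.
Compound 3, `COc1cc2c(cc1OC)C(CC(=O)NC1CCCC1)CC2`, gives 40.7% in this assay.

Compound 3 stands highest of the three, and its steps to both others lie beyond the scatter: a number 12.9 percentage points higher from compound 1 to compound 3 (beyond the scatter) and a number 16.6 percentage points higher from compound 2 to compound 3 (beyond the scatter). The step from compound 1 to compound 2 was a number 3.7 percentage points lower from compound 1 to compound 2 (within the scatter). Compound 4, `COc1cc2c(cc1OC)C(CC(=O)NC1CCCCC1)CC2`, differs from compound 3 by cyclohexyl in place of cyclopentyl on an amide-type nitrogen. Within the data shown here, both measured steps that enlarged the group on that nitrogen raised the number, but no measured step goes from one ring to a larger ring, so these steps bear only loosely here. An expected step of a number 2.3 percentage points higher from compound 3 to compound 4 (within the scatter) in this assay is within the scatter. Compound 4 is therefore estimated at 43%, with a range from 28% to 58%.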

Compound 4, a percentage reported as inhibition, in the whole organism at one dose (the size of the read-out at that dose, not a potency): 48.2%
Compound 4: middle estimate off by 5.2 percentage points, on the low side; low and high end bracket the measured number.
By their numbers in this assay, from the lowest: compounds 2 and 1 (each within the scatter of the next); then compounds 3 and 4 (each within the scatter of the next).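

In this assay, enlarging the ring on the amide-type nitrogen from cyclopentyl to cyclohexyl gives a step within the scatter (a number 7.5 percentage points higher from compound 3 to compound 4 (within the scatter)), so these two rings cannot be told apart here. Cyclohexyl, like cyclopentyl, stands clear of both smaller groups on that nitrogen, methyl (a number 24.1 percentage points higher from compound 2 to compound 4 (beyond the scatter)) and hydrogen (a number 20.4 percentage points higher from compound 1 to compound 4 (beyond the scatter)). No evidence is available that explains these numbers.

From the compounds shown here alone, what remains open is whether a larger ring such as cycloheptyl, or an aromatic ring such as phenyl, on the same nitrogen would read differently.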